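The source may report more compounds than this note shows. Statements on the series, on what has been measured and on what is new or still open speak of the compounds shown alone.

Compounds measured in a functional assay on HCT-116 cells (Homo sapiens) for cytotoxicity, read by MTT assay, with a stated time of 48 h; a higher number here means a weaker inhibitor, a lower number a stronger inhibitor:
- compound 1 `CN(C)CCCCCSC1=Nc2ccccc2C(CC(=O)NCc2ccc(F)cc2)N1c1ccc(-c2ccccc2)cc1`: 6400 nM
- compound 2 `O=C(CC1c2ccccc2N=C(SCCCCCN2CCCC2)N1c1ccc(-c2ccc(F)cc2)cc1)NCc1ccc(F)cc1`: 7700 nM
- compound 3 `CN(C)CCCCCSC1=Nc2ccccc2C(CC(=O)NCc2ccccc2)N1c1ccccc1`: 38800 nM

Compound 1 gives the lowest of the three numbers; its gap to compound 2 lies within the scatter, while compound 3 stands beyond it. Compound 4 `CN(C)CCCCCSC1=Nc2ccccc2C(CC(=O)NCc2ccc(F)cc2)N1c1ccccc1` has not yet been measured. It differs from compound 1 in one place: hydrogen in place of phenyl on an aromatic carbon Compound 3 also carries a phenyl on the ring nitrogen and gives 38800 nM, so the weakening seen there is expected to carry over to compound 4. The step of a 3.9-fold higher number from compound 1 to compound 4 (0.59 log units; beyond the scatter) is therefore expected to go toward a higher number, beyond the scatter. For compound 4 the estimate is 25000 nM, within 10000 nM to 60000 nM.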

Compound 4, half-maximal inhibitory concentration: 38800 nM
Compound 4: middle estimate off by 1.6-fold (0.19 log units), on the low side, within the range that was stated.
By their numbers in this assay, from the lowest: compounds 1 and 2 (each within the scatter of the next); then compounds 3 and 4 (each within the scatter of the next).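

In this assay, among the compounds shown here, hydrogen in place of phenyl on an aromatic carbon gives a 6.1-fold higher number from compound 1 to compound 4 (0.78 log units; beyond the scatter), the first one-place step to show that the change from 4-phenylphenyl to phenyl moves the number beyond the scatter. The fluoro change gives no change at the digits printed from compound 3 to compound 4 (within the scatter), so with phenyl in place, fluoro in place of hydrogen shows no effect in this assay. Nothing available explains either result. The compounds shown leave open whether a methoxy group or a chlorine atom in place of the outer phenyl would keep the lower number. They also leave open whether the fluoro change would remain without effect alongside 4-phenylphenyl.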